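Fluoro to Methyl on the Piperidine Urea

The compounds below may be only part of what the source reports. "The series", "measured", "known", "first", "only" and "open" are said of these compounds alone.

In an assay on HEK293 cells for negative allosteric modulation of metabotropic glutamate receptor 5 (Homo sapiens), read by FLIPR (a lower number here means a stronger inhibitor, a higher number a weaker inhibitor), compound 1 `Cc1cccc(-c2noc(C3CN(S(=O)(=O)c4cccc(C)c4)C3)n2)c1` gives 650 nM. Compound 3 `O=S(=O)(c1ccc(F)cc1)N1CC(c2nc(-c3cccc(Cl)c3)no2)C1` gives 130 nM in this assay. Both carry a sulfonyl group on the shared core, whereas compound 2 `O=C(N1CCC(F)CC1)N1CC(c2nc(-c3cccc(Cl)c3)no2)C1` carries a urea in that position. For compound 2 this assay reports only a limit, > 10000 nM, and not a number (the limit of > 10000 nM in this assay, at which 1 of the 3 values shown sits). Compound 2 thus stands at the weak end of the values shown, without an exact figure of its own. Compound 4 `CC1CCN(C(=O)N2CC(c3nc(-c4cccc(Cl)c4)no3)C2)CC1` is the unmeasured partner of compound 2; the difference between them is methyl in place of fluoro on a saturated ring carbon. Within the data shown here, no measured pair shows this exact change, and the size of the step can only be expected, not read off. The step that the limit leaves unreadable from compound 2 to compound 4 is expected to stay within the scatter, or at most to move a little in either direction. Compound 4 is therefore estimated at 15000 nM, with a range from 3000 nM to 50000 nM, and the assay is expected most likely to report again only a limit for compound 4.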

Compound 4, half-maximal inhibitory concentration: > 10000 nM
Compound 4 ended at the assay's limit (the forecaster's own chance of this, stated with the estimate: 70%); the middle value is on the limit's open side.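

The result for compound 4 in this assay is a limit, as is that for compound 2, so no step can be read between the two: the limit of > 10000 nM in this assay, at which 2 of the 4 values shown sit.

The compounds shown leave open whether 4-fluoropiperidin-1-yl and 4-methylpiperidin-1-yl differ at all in this assay.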